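The source may hold more compounds than are shown below. What is called first, only, known or untested is meant among the compounds shown, and "the series" means these compounds.

Compound 1 `Nc1scc(CN2CCN(c3ccc(Cl)cc3Cl)CC2)c1C(=O)c1ccc(Cl)cc1` is the reference point of this account. In a functional assay on CHO cells with adenosine receptor A1 (Homo sapiens) as the target, read by cAMP accumulation and immunoassay, with a stated time of 6 min, tested at 0.01 uM (on this read-out lower numbers stand for a stronger effect and higher numbers for a weaker effect at the one concentration tested), compound 1 gives 2%, which places it highest of the two numbers measured, though its nearest neighbour sits within the usual scatter. For the measured compounds named here, that neighbour is compound 2 `COc1ccc(N2CCN(Cc3csc(N)c3C(=O)c3ccc(Cl)cc3)CC2)cc1`, which in this assay gives -1.2%; the only measured step, a number 3.2 percentage points lower from compound 1 to compound 2 (within the scatter), changes the same part of the molecule that is changed here, so it bears directly on the question, and it was too small to count as a real change. The compound now to be measured is compound 3 `Nc1scc(CN2CCN(c3cccc(C(F)(F)F)c3)CC2)c1C(=O)c1ccc(Cl)cc1`, which differs from compound 1 in one place: 3-(trifluoromethyl)phenyl in place of 2,4-dichlorophenyl on an amine nitrogen in a ring. Going by the values given here, since the one comparable step at this position left the read-out within the scatter, and the read-out for both measured compounds is close to zero, the step from compound 1 to compound 3 is expected to be none beyond the scatter, that is a number 1 percentage points lower from compound 1 to compound 3 (within the scatter). For compound 3 the estimate in this assay is therefore 1%, with a range from -10% to 12%.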

Compound 3, a percentage reported as activity, at one concentration (the size of the read-out at that concentration, not a potency): -8.2%
For compound 3 the middle estimate is 9.2 percentage points above the measured one; measured number inside the range.
By their numbers in this assay, from the lowest: compounds 3, 2 and 1 (each within the scatter of the next, the first and the last beyond it).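

In this assay, for the compounds shown here, the aryl group on the amine nitrogen in a ring had so far given only a step within the scatter, but a number 10.2 percentage points lower from compound 1 to compound 3 (beyond the scatter) shows that a change at this position can move the read-out beyond it at the one concentration tested. This holds for that pair alone and remains a modest shift: a number 7 percentage points lower from compound 2 to compound 3 (within the scatter) keeps 3-(trifluoromethyl)phenyl and 4-methoxyphenyl apart by no more than the scatter, so the three compounds do not form a clear ranking of these groups, and only compound 1 and compound 3 can be separated. Nothing shown here gives a reason for the step between them. From the compounds shown here alone, it remains open whether the trifluoromethyl group itself matters or whether the loss of the two chlorines from the 2,4-dichlorophenyl group is enough, which a plain phenyl group at this position could help to separate. Also open, going by these compounds, is how a nitrile or a carboxylic acid on that phenyl ring would read, and whether this single-concentration difference would carry over to a measure of potency.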